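A few compounds are considered here, and "the series" means these few. Any claim that something is new, unique, unknown or untested is made for them only; others in the source may bear on it.

Measured in a functional assay on PC-3 cells (Homo sapiens) for inhibition, read by sulforhodamine B assay, with a stated time of 48 h; on this read-out lower numbers stand for higher toxicity in this test and higher numbers for lower toxicity in this test:
- Compound 1 `COc1cc(-c2nn(-c3cccc(NC(=O)Nc4ccc(Cl)c(Cl)c4)c3)cc2-c2ccncc2)ccc1Cl`: > 50000 nM, a limit
- Compound 2 `O=C(Nc1cccc(-n2cc(-c3ccncc3)c(-c3ccc(Cl)c(O)c3)n2)c1)Nc1ccc(Cl)c(Cl)c1`: > 32500 nM, a limit
- Compound 3 `O=C(Nc1cccc(-n2cc(-c3ccncc3)c(-c3ccc(Cl)c(O)c3)n2)c1)Nc1cc(C(F)(F)F)cc(C(F)(F)F)c1`: > 50000 nM, a limit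

Compound 1 has no number in this assay, only a limit. The same holds for the other two compounds, so the three cannot be ranked against one another.

Compound 4 `COc1cc(-c2nn(-c3cccc(NC(=O)c4ccccc4)c3)cc2-c2ccncc2)ccc1Cl` keeps the core of compound 1 and changes one end of the molecule: phenyl in place of (3,4-dichlorophenyl)amino on a carbonyl carbon. On a carbonyl carbon, phenyl takes the place of (3,4-dichlorophenyl)amino, which turns ((3,4-dichlorophenyl)carbamoyl)amino into benzamido.

For the measured compounds named here, the only measured step is a step that the two limits leave unreadable from compound 1 to compound 2. It lies in a different place, on an oxygen on an aromatic ring, and its size cannot be read, so it offers no guide to this change.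

The expectation therefore rests on the starting point. Compound 1 stands at > 50000 nM, which is a limit. No step beyond the scatter is expected, and the estimated step is a number no higher from compound 1 to compound 4 (the limit leaves the size open). The result may well be reported as a limit again. The estimate for compound 4 is 50000 nM, with an expected range of 25000 nM to 100000 nM.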

Compound 4, concentration lethal to 50% of the cells: > 100000 nM
Compound 4: a limit, no number; the forecaster's own chance of this, stated with the estimate: 80%; at least 2.0-fold (0.30 log units) between middle value and limit.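

In this assay compound 4 gives > 100000 nM, which is a limit and not a number. For the compounds shown here, compound 1 also carries only a limit, and no step from compound 1 to compound 4 can be read. The compounds shown leave open what phenyl in place of (3,4-dichlorophenyl)amino does to toxicity, and at what concentration any of them would reach the lethal read-out of this test.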